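Halogen position on the anilino ring and cell inhibition

The source may report more compounds than this note shows. Statements on the series, on what has been measured and on what is new or still open speak of the compounds shown alone.

For the measured compounds named here, compound 2 `Cc1n[nH]c2ccc(-c3nc4cnc(N5CCN(C)CC5)cn4c3Nc3cccc(Cl)c3)cc12` gives 0% in a functional assay on MV4-11 cells (Homo sapiens) for inhibition, with a stated time of 120 h, tested at 10 uM (on this read-out higher numbers stand for more inhibition at the one concentration tested (going by the name of the read-out) and lower numbers for less inhibition), the lowest of the two numbers known here. Compound 1 `Cc1n[nH]c2ccc(-c3nc4cnc(N5CCN(C)CC5)cn4c3Nc3ccccc3Cl)cc12`, which carries a 2-chlorophenyl on the same nitrogen, gives 58.1% in this assay , and the step of a number 58.1 percentage points lower from compound 1 to compound 2 (beyond the scatter) shows how strongly a move of the chlorine on that ring changed the read-out. Compound 3 `Cc1n[nH]c2ccc(-c3nc4cnc(N5CCN(C)CC5)cn4c3Nc3ccc(I)cc3)cc12` is compound 2 with 4-iodophenyl in place of 3-chlorophenyl on a nitrogen on an aromatic ring. Going by the values given here, no measured step covers this exact change; the only step known, from compound 1 to compound 2, shows that the substitution pattern on this ring can swing the read-out across most of its span. Compound 3 is therefore expected to give 12%, a step of a number 12 percentage points higher from compound 2 to compound 3 (beyond the scatter), with a wide range from 0% to 45% because compound 2 sits at 0% and the direction of the change is uncertain.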

Compound 3, a percentage reported as inhibition, at one concentration (the size of the read-out at that concentration, not a potency): 0%
Estimate against measurement, compound 3: 12 percentage points above; low and high end bracket the measured number.
By their numbers in this assay, from the lowest: compounds 2 and 3 (each within the scatter of the next); then compound 1.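

In this assay, the change to 4-iodophenyl gives no change at the digits printed from compound 2 to compound 3 (within the scatter), so this group leaves the read-out where the 3-chlorophenyl put it. The same group, set against the 2-chlorophenyl, gives a number 58.1 percentage points lower from compound 1 to compound 3 (beyond the scatter), which leaves compound 1 as the only one of the three with measurable inhibition at the one concentration tested. The change from compound 2 to compound 3 swaps the halogen and its place on the ring together, and with both numbers at the bottom of the read-out, the two changes cannot be told apart.

No evidence is available to explain these differences. Still open, going by these compounds, is how this ring behaves as an unsubstituted phenyl, or with a methoxy group or an amine in place of the halogen.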